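A large triazole replaces hydroxy at the stability limit

The source may hold more compounds than are shown below. What is called first, only, known or untested is meant among the compounds shown, and "the series" means these compounds.

compound 1 `COc1ccc(-c2c(C)nc3c(N4CC[C@@H](NC(=O)C(F)(F)F)C4)cc(C)nn23)cc1OC` gives > 95% (a limit)
compound 2 `COc1ccc(-c2c(C)nc3c(N4CC[C@@H](NS(=O)(=O)c5cccs5)C4)cc(C)nn23)cc1OC` gives > 95% (a limit)
compound 3 `COc1ccc(-c2c(C)nc3c(N4CC[C@@H](O)C4)cc(C)nn23)cc1OC` gives > 95% (a limit)

In an ADME assay on microsomes from liver (Mus musculus) for metabolic stability, read by LC-MS, with NADPH named in the record, with a stated time of 60 min, tested at 1 uM, in the absence of a further agent (on this read-out higher numbers stand for a more stable compound and lower numbers for a less stable compound), compound 3 gives > 95% as a limit, not a number. Compound 4 `COc1ccc(-c2c(C)nc3c(N4CC[C@@H](n5cc(-c6ccccc6)nn5)C4)cc(C)nn23)cc1OC` carries 4-phenyl-1H-1,2,3-triazol-1-yl in place of hydroxy on a saturated ring carbon. Going by the values given here, the steps that bear on this are a step that the two limits leave unreadable from compound 1 to compound 3 and a step that the two limits leave unreadable from compound 2 to compound 3 (neither has a readable size). All three values share one limit (the limit of > 95% in this assay, at which 3 of the 3 values shown sit). Compound 2 carries a ring-bearing group on that carbon and still gives > 95% as a limit, so little change is expected. The expected step is a number at least 3 percentage points lower from compound 3 to compound 4 (that floor lies within the scatter) (a small fall, or none beyond the scatter). The estimate for compound 4 is 92% (expected range 75% to 100%).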

Compound 4, percent of the compound remaining: "unstable" (no number reported)
Nothing numeric was reported for compound 4; no gap can be computed for the estimate.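

In this assay, going by these compounds alone, compound 4 is recorded only as unstable, without a number, so no step from compound 3 to compound 4 can be read. The compounds shown leave open how much of compound 4 remains.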